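A methoxy-to-chloro swap on the shared core

The source may hold more compounds than are shown below. What is called first, only, known or untested is meant among the compounds shown, and "the series" means these compounds.

compound 1 `COc1ccc2nc(NC(c3cn(-c4ccccc4)nc3-c3ccc(Cl)cc3)c3c(O)ccc4ccccc34)sc2c1` gives 5200 nM
compound 2 `COc1ccc2nc(NC(c3cn(-c4ccccc4)nc3-c3cccc(I)c3)c3c(O)ccc4ccccc34)sc2c1` gives 6240 nM

In a functional assay on HeLa cells (Homo sapiens) for antiproliferative activity, read by MTT assay, with a stated time of 48 h (on this read-out lower numbers stand for stronger inhibition and higher numbers for weaker inhibition), compound 1 has only compound 2 as a neighbour, and the two cannot be ranked: between them lies a 1.2-fold higher number from compound 1 to compound 2 (0.08 log units; within the scatter) for 3-iodophenyl in place of 4-chlorophenyl on an aromatic carbon.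

Compound 3 `Oc1ccc2ccccc2c1C(Nc1nc2ccc(Cl)cc2s1)c1cn(-c2ccccc2)nc1-c1ccc(Cl)cc1` keeps the core of compound 1 and differs in one place (chloro in place of methoxy on an aromatic carbon), with chloro in place of methoxy on an aromatic carbon, so that 6-methoxy-1,3-benzothiazol-2-yl becomes 6-chloro-1,3-benzothiazol-2-yl.

Among the measured compounds shown here, no measured step touches this position. For the measured compounds named here, the single step available changes a different group, so it says nothing direct about this swap, and it offers only a weak hint that the series may sit in a narrow band. The data give no direction for the change, and no step beyond the scatter is expected in this assay on this evidence. The estimated step is a 1.0-fold lower number from compound 1 to compound 3 (0.02 log units; within the scatter) and it rests on the absence of any contrary measurement. For compound 3 the expected value is 5000 nM with an estimated range from 1800 nM to 14000 nM in this assessment.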

Compound 3, half-maximal inhibitory concentration: 36800 nM
Compound 3: middle estimate off by 7.4-fold (0.87 log units), on the low side; measured number outside the range, above it.
By their numbers in this assay, from the lowest: compounds 1 and 2 (each within the scatter of the next); then compound 3.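

In this assay, among the compounds shown here, the 6-position group of the benzothiazole is the first place where a single change moves the number beyond the scatter, with a 7.1-fold higher number from compound 1 to compound 3 (0.85 log units; beyond the scatter) for chloro in place of methoxy on the six-membered aromatic ring of carbon only. For the compounds shown here, the earlier change at a different place, a 1.2-fold higher number from compound 1 to compound 2 (0.08 log units; within the scatter), stayed within the scatter, so the narrow band hinted at by compound 1 and compound 2 does not extend to this position, and the methoxy compound is the one with the lower number in this pair. Nothing measured here speaks to why this swap shifts the number in this direction.

The compounds shown leave open whether the shift follows from the arrival of chloro or the departure of methoxy, a question that a plain hydrogen, a hydroxy, an ethoxy or an amine at the same place could help to settle. They also leave open whether the same swap would give a step of similar size on the 3-iodophenyl background of compound 2.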